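One fluoro substitution on compound 3

The source may hold more compounds than are shown below. What is called first, only, known or untested is meant among the compounds shown, and "the series" means these compounds.

- compound 1 `O=C(NO)c1ccc(/C=C/c2ccnc(-c3ccccc3O)c2)cc1` gives 1450 nM
- compound 2 `O=C(NO)c1ccc(/C=C/c2ccnc(-c3cccnc3)c2)cc1` gives 5140 nM
- compound 3 `Cc1ccc(-c2cc(/C=C/c3ccc(C(=O)NO)cc3)ccn2)cc1` gives 2390 nM

In a functional assay on HCT-116 cells (Homo sapiens) for antiproliferative activity, read by CellTiter-Glo, with a stated time of 72 h (a lower number here means a stronger inhibitor, a higher number a weaker inhibitor), compound 3 gives 2390 nM. Its nearest gap is a 1.6-fold higher number from compound 1 to compound 3 (0.22 log units; within the scatter) and its furthest is a 2.2-fold lower number from compound 2 to compound 3 (0.33 log units; beyond the scatter). Compound 4 `Cc1ccc(-c2cc(/C=C/c3ccc(C(=O)NO)cc3)c(F)cn2)cc1` carries fluoro in place of hydrogen on an aromatic carbon. Among the measured compounds shown here, no measured step touches that carbon. All three exchange only 2-hydroxyphenyl, pyridin-3-yl or 4-methylphenyl, and the largest, a 3.5-fold higher number from compound 1 to compound 2 (0.55 log units; beyond the scatter), is modest and says little about this change. No step beyond the scatter is therefore expected in this assay, and no direction can be favoured. The expected step is a 1.1-fold lower number from compound 3 to compound 4 (0.04 log units; within the scatter). The estimated value for compound 4 is 2200 nM, with an expected range of 1000 nM to 4800 nM.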

Compound 4, half-maximal inhibitory concentration: > 10000 nM
Compound 4: a limit, no number (the forecaster's own chance of this, stated with the estimate: 3%); at least 4.5-fold (0.65 log units) between middle value and limit.
By their numbers in this assay, from the lowest: compounds 1 and 3 (each within the scatter of the next); then compound 2. At a limit, above all of these: compound 4.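

Fluoro in place of hydrogen, on the aromatic carbon ortho to a large group and two atoms from the ring nitrogen, is the only change shown at this carbon, and in this assay it gives an at least 4.1-fold higher number from compound 3 to compound 4 (0.62 log units; beyond the scatter). This carbon, untouched by the exchanges of 2-hydroxyphenyl, pyridin-3-yl and 4-methylphenyl, is therefore not indifferent to substitution. Compound 4 stands at a limit, not a number: the limit of > 10000 nM in this assay, at which 1 of the 4 values shown sits.

Going by these compounds, how far the weakening goes remains open. The compounds shown also do not tell whether chloro, methyl or methoxy on the same carbon would behave like fluoro.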